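The source may hold more compounds than are shown below. What is called first, only, known or untested is meant among the compounds shown, and "the series" means these compounds.

Three esters of the shared core have been run in an assay on HEK293T cells for inhibition of nuclear factor NF-kappa-B complex (Homo sapiens), read by a luciferase reporter; on this read-out lower numbers stand for stronger inhibition and higher numbers for weaker inhibition. Compound 1 `COc1cc2c(c(O)c1C(=O)/C=C/c1ccc(OC(=O)c3cccs3)cc1)CCC(C)(C)O2` returns only the assay limit, > 30000 nM. Compound 2 `COc1cc2c(c(O)c1C(=O)/C=C/c1ccc(OC(=O)c3ccc(Cl)nc3)cc1)CCC(C)(C)O2` likewise returns a limit, > 30000 nM. Compound 3 `COc1cc2c(c(O)c1C(=O)/C=C/c1ccc(OC(=O)c3ccc(OC(F)(F)F)cc3)cc1)CCC(C)(C)O2` also sits at a limit, > 30000 nM. Compound 3 therefore stands where every value shown stands, namely at the limit of > 30000 nM in this assay, at which 3 of the 3 values shown sit. Compound 4 `COc1cc2c(c(O)c1C(=O)/C=C/c1ccc(OC(C)=O)cc1)CCC(C)(C)O2` carries methyl in place of 4-(trifluoromethoxy)phenyl on a carbonyl carbon. The measured steps that bear on this change at the carbonyl carbon, a step that the two limits leave unreadable from compound 1 to compound 3 and a step that the two limits leave unreadable from compound 2 to compound 3, are both unreadable between limits, so neither size nor direction can be taken from them. Compound 4 is expected at 30000 nM, with a range from 8000 nM to 120000 nM, most probably again as a limit. The step of a number no higher from compound 3 to compound 4 (the limit leaves the size open) is accordingly expected to be one this assay cannot read.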

Compound 4, half-maximal inhibitory concentration: > 30000 nM
Compound 4 gave a limit, no number; the forecaster's own chance of this, stated with the estimate: 75%; the middle value sits exactly at the limit.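

In this assay no step among compound 1, compound 2, compound 3 and compound 4 can be read, since compound 4 also gave only a limit: the limit of > 30000 nM in this assay, at which 4 of the 4 values shown sit.

The compounds shown leave open whether any ester of the shared core reaches a measurable value, and what the group on the carbonyl carbon contributes.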